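A few compounds are considered here, and "the series" means these few. Any claim that something is new, unique, unknown or untested is made for them only; others in the source may bear on it.

In a functional assay on HEK293 cells for agonist activity at G-protein coupled receptor 39 (Homo sapiens), read by scintillation proximity assay and inositol phosphate accumulation, with a stated time of 75 min, in the presence of a further agent that is not named here (a lower number here means that less compound is needed, a higher number that more compound is needed for the effect), the three measured compounds gave the following numbers:

Compound 1 `Cc1nn(-c2ncnc3nc[nH]c23)c2c1C(OCc1ccccc1C#N)CC(=O)N2`: 8 nM
Compound 2 `Cc1nn(-c2ncnc3nc[nH]c23)c2c1C(c1ccc(OC(C)C)cc1)CC(=O)N2`: 18 nM
Compound 3 `Cc1nn(-c2ncnc3nc[nH]c23)c2c1C(OCCn1nccc1C)CC(=O)N2`: 10 nM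

Compound 3 stands second highest of the three. Its nearest neighbour is compound 1, with a 1.3-fold higher number from compound 1 to compound 3 (0.10 log units; within the scatter), and its furthest is compound 2, with a 1.8-fold lower number from compound 2 to compound 3 (0.26 log units; within the scatter). Among the compounds with values here, the one step that does go beyond the scatter is a 2.3-fold higher number from compound 1 to compound 2 (0.35 log units; beyond the scatter).

Compound 4 `Cc1nn(-c2ncnc3nc[nH]c23)c2c1C(OCCn1cccn1)CC(=O)N2` differs from compound 3 in a single place: hydrogen in place of methyl on an aromatic carbon.

Within the data shown here, no measured step removes a methyl from that ring, so nothing bears on the change directly. What the measured steps do show is that swapping the entire side group on the shared core, as in a 1.3-fold higher number from compound 1 to compound 3 (0.10 log units; within the scatter) and a 1.8-fold lower number from compound 2 to compound 3 (0.26 log units; within the scatter), moves the number only within the scatter. A change far smaller than those is therefore expected to give no step beyond the scatter in this assay. The estimated step of a 1.2-fold higher number from compound 3 to compound 4 (0.08 log units; within the scatter) is expected to lie within the scatter. Compound 4 is accordingly estimated to give 12 nM, with a range from 5 nM to 30 nM.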

Compound 4, half-maximal effective concentration: 16 nM
Compound 4: middle estimate off by 1.3-fold (0.12 log units), on the low side, within the range that was stated.
By their numbers in this assay, from the lowest: compounds 1, 3, 4 and 2 (each within the scatter of the next, the first and the last beyond it).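

In this assay, within the data shown here, the step that takes the methyl away (a 1.6-fold higher number from compound 3 to compound 4 (0.20 log units; within the scatter)) is the first direct reading at this aromatic carbon, and it stays within the scatter, so the number does not depend measurably on this methyl. The 2-(1H-pyrazol-1-yl)ethoxy group of compound 4 also cannot be told apart from the side groups of the other two compounds (a 1.1-fold lower number from compound 2 to compound 4 (0.05 log units; within the scatter) and a 2.0-fold higher number from compound 1 to compound 4 (0.30 log units; within the scatter)), even though those two compounds differ from each other beyond the scatter. No measurement offers an explanation for how small these steps are.

As far as these compounds go, whether an ethyl group or a chlorine atom on that aromatic carbon would also leave the number unchanged remains open. So does the effect of a longer chain carrying the 1H-pyrazol-1-yl group, or of an amine in place of that ring.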